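Hydroxyphenyl position and cytotoxicity across four compounds

A few compounds are considered here, and "the series" means these few. Any claim that something is new, unique, unknown or untested is made for them only; others in the source may bear on it.

Compound 1 `Oc1cccc(-c2cc(-c3ccoc3)cc(-c3ccccc3O)n2)c1` gives 2790 nM in a functional assay on DU-145 cells (Homo sapiens) for cytotoxicity, read by CCK-8 assay; a higher number here means a weaker inhibitor, a lower number a stronger inhibitor. Compound 2 `Oc1ccc(-c2cc(-c3ccoc3)cc(-c3ccccc3O)n2)cc1` gives 28000 nM; the change 4-hydroxyphenyl in place of 3-hydroxyphenyl on an aromatic carbon made a 10-fold higher number from compound 1 to compound 2 (1.00 log units; beyond the scatter). Compound 3 `Oc1cccc(-c2cc(-c3ccoc3)cc(-c3cccc(O)c3)n2)c1` gives 1650 nM; the cores of compound 3 and compound 1 differ by 3-hydroxyphenyl in place of 2-hydroxyphenyl on an aromatic carbon, which made a 1.7-fold lower number from compound 1 to compound 3 (0.23 log units; within the scatter). Compound 4 `Oc1ccc(-c2cc(-c3ccoc3)cc(-c3cccc(O)c3)n2)cc1` is not yet measured in this assay ; it differs from compound 3 by 4-hydroxyphenyl in place of 3-hydroxyphenyl on an aromatic carbon. This is the same kind of change as that from compound 1 to compound 2, not the same: in compound 1 the place is meta to a 2-hydroxyphenyl group, in compound 3 it is meta to a 3-hydroxyphenyl group. A step of similar size is expected, a 7.9-fold higher number from compound 3 to compound 4 (0.90 log units; beyond the scatter), because the same kind of change gave a 10-fold higher number from compound 1 to compound 2 (1.00 log units; beyond the scatter). For compound 4 the expected value is 13000 nM, estimated between 5000 nM and 35000 nM.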

Compound 4, half-maximal inhibitory concentration: 2700 nM
For compound 4 the middle estimate is 4.8-fold (0.68 log units) above the measured one; the whole stated range lies above it.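

In this assay, 4-hydroxyphenyl in place of 3-hydroxyphenyl gave a 1.6-fold higher number from compound 3 to compound 4 (0.21 log units; within the scatter), so this change does not carry over at a constant size from one core to the other: the same change on two cores in this assay, a 10-fold higher number (1.00 log units; beyond the scatter) from compound 1 to compound 2 and a 1.6-fold higher number (0.21 log units; within the scatter) from compound 3 to compound 4, 6.1-fold (0.79 log units) apart, beyond the scatter of two such steps

The same holds for 3-hydroxyphenyl in place of 2-hydroxyphenyl, which gave a 10-fold lower number from compound 2 to compound 4 (1.02 log units; beyond the scatter): the same change on two cores in this assay, a 1.7-fold lower number (0.23 log units; within the scatter) from compound 1 to compound 3 and a 10-fold lower number (1.02 log units; beyond the scatter) from compound 2 to compound 4, 6.1-fold (0.79 log units) apart, beyond the scatter of two such steps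

Alongside a 1.0-fold lower number from compound 1 to compound 4 (0.01 log units; within the scatter), this places the steps beyond the scatter on compound 2, the one compound pairing 4-hydroxyphenyl with 2-hydroxyphenyl, but two cores per change show neither why the steps differ nor how either change would behave on a further core.

On these data alone, all four compounds carry the furan-3-yl group, so its contribution remains open. Also open, as far as these compounds go, is what an amine or a carboxylic acid in place of a hydroxyl would do.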